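Aryl variation on the piperidinyl-pyrimidine sulfamide series

A few compounds are considered here, and "the series" means these few. Any claim that something is new, unique, unknown or untested is made for them only; others in the source may bear on it.

Measured compounds in a functional assay on M21 cells (Homo sapiens) for antiproliferative activity, read by sulforhodamine B assay, with a stated time of 48 h; on this read-out higher numbers stand for weaker inhibition of growth and lower numbers for stronger inhibition of growth:
compound 1 `Cc1ccc(-c2cc(N3CCC(CNS(N)(=O)=O)CC3)ncn2)cc1`: 71000 nM
compound 2 `Cc1ccc(-c2cc(N3CCC(CCNS(N)(=O)=O)CC3)ncn2)cc1`: 57600 nM
compound 3 `CCOC(=O)c1ccc(-c2cc(N3CCC(CCNS(N)(=O)=O)CC3)ncn2)cc1`: 9000 nM

Compound 2 stands second highest of the three numbers in this assay. Its nearest neighbour is compound 1, with a 1.2-fold lower number from compound 1 to compound 2 (0.09 log units; within the scatter) separating them, a step that stays within the scatter. For the measured compounds named here, compound 3 is furthest away, reached through a 6.4-fold lower number from compound 2 to compound 3 (0.81 log units; beyond the scatter), the only step beyond the scatter in the set.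

Compound 4 `NS(=O)(=O)NCCC1CCN(c2cc(-c3cccc(Cl)c3)ncn2)CC1` differs from compound 2 by 3-chlorophenyl in place of 4-methylphenyl on an aromatic carbon. Going by the values given here, the one measured step that touches the aryl group, the step from compound 2 to compound 3, swaps methyl for ethoxycarbonyl; the group that enters in compound 4 is 3-chlorophenyl instead, so that step only loosely bears on the change. Among the compounds with values here, no measured pair shows a chloro substituent or a 3-substituted ring. The expectation for compound 4 in this assay is therefore a step of a 1.4-fold lower number from compound 2 to compound 4 (0.16 log units; within the scatter), most likely within the scatter, with a small lean toward a lower number by analogy with compound 3.

Compound 4 is estimated at 40000 nM, within a range from 12000 nM to 120000 nM.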

Compound 4, concentration for 50% growth inhibition: 50700 nM
Beside the measured number, compound 4's estimate is 1.3-fold (0.10 log units) below it; low and high end bracket the measured number.
By their numbers in this assay, from the lowest: compound 3; then compounds 4, 2 and 1 (each within the scatter of the next).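

In this assay, 3-chlorophenyl in place of 4-methylphenyl on this aromatic carbon gives a 1.1-fold lower number from compound 2 to compound 4 (0.06 log units; within the scatter), so this exchange leaves no readable mark on the read-out. Moving the substituent and changing it from methyl to chloro at once therefore does not separate compound 4 from compound 2, while ethoxycarbonyl in place of methyl remains the only aryl change beyond the scatter, with a 6.4-fold lower number from compound 2 to compound 3 (0.81 log units; beyond the scatter). No available measurement bears on why the two aryl groups read alike.

Still open, as far as these compounds go, is whether a carboxylic acid or a primary amide in place of the ethoxycarbonyl would keep the step seen with compound 3. Also open, from the compounds shown here alone, is whether 4-chlorophenyl would read like 3-chlorophenyl, which would separate the effect of the chlorine from that of its ring position.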